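Working notes: chloro in place of methyl on compound 2

This account rests on a few compounds, and the source may have more. Where it says the series, first, only, none or still open, it means among the compounds named here.

Values so far in a functional assay on HeLa cells (Homo sapiens) for inhibition, read by CCK-8 assay, with a stated time of 72 h, tested at 2 uM (on this read-out higher numbers stand for more inhibition of growth at the one concentration tested and lower numbers for less inhibition of growth), for the three measured compounds:
compound 1 `CCc1ccc(SCc2ccc(C(=O)Nc3ccccc3N)cc2)cc1` gives 30.8%
compound 2 `Cc1ccc(SCc2ccc(C(=O)Nc3ccccc3N)cc2)cc1` gives 33.8%
compound 3 `COC(=O)c1ccccc1SCc1ccc(C(=O)Nc2ccccc2N)cc1` gives 29.8%

All three numbers lie within the scatter of one another, so compound 2 at 33.8% has no separate standing in this assay and serves only as the reference point here.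

Compound 4 `Nc1ccccc1NC(=O)c1ccc(CSc2ccc(Cl)cc2)cc1` follows from compound 2 by a single exchange (chloro in place of methyl on an aromatic carbon), chloro in place of methyl on an aromatic carbon, para to a large group, so that 4-methylphenyl becomes 4-chlorophenyl.

Going by the values given here, one measured step bears on this: a number 3 percentage points higher from compound 1 to compound 2 (within the scatter) touches the group at the same place and stays within the scatter. Compound 3 at 29.8% carries a different group on that ring and also lies within the scatter of compound 2. Among the compounds with values here, no measured compound carries chloro, so a direct comparison is lacking.

No step beyond the scatter is expected in this assay in either direction, and the estimated a number 1.8 percentage points lower from compound 2 to compound 4 (within the scatter) stays inside it. For compound 4 the estimated value is 32%, with an expected range from 22% to 44% on this read-out.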

Compound 4, percent growth inhibition at one concentration: 19.2%
Beside the measured number, compound 4's estimate is 12.8 percentage points above it; the whole stated range lies above it.
By their numbers in this assay, from the lowest: compound 4; then compounds 3, 1 and 2 (each within the scatter of the next).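

In this assay, going by these compounds alone, the change of methyl to chloro on an aromatic carbon, para to a large group, gives the first step beyond the scatter at this position: a number 14.6 percentage points lower from compound 2 to compound 4 (beyond the scatter). The change of ethyl to chloro at the same place agrees with it, with a number 11.6 percentage points lower from compound 1 to compound 4 (beyond the scatter), whereas the earlier exchange of ethyl for methyl gave only a number 3 percentage points higher from compound 1 to compound 2 (within the scatter), so this place is not indifferent to the group it carries, even though methyl and ethyl could not be told apart there. Nothing available bears on why chloro lowers the number relative to these two alkyl groups.

The compounds shown do not tell whether the lower growth inhibition is particular to chloro or would also appear with fluoro, bromo or methoxy on the same carbon. They also leave open whether 4-chlorophenyl differs from 4-methylphenyl by a similar margin across a range of concentrations, since each value here comes from a single concentration.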